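Fluoro to methoxy on the core of compound 1

The compounds below may be only part of what the source reports. "The series", "measured", "known", "first", "only" and "open" are said of these compounds alone.

Measured so far:
Compound 1 `O=C(O)c1cnc2c(F)cccc2c1` — in a functional assay on the whole organism (strain Sprague-Dawley) for inhibition, with Rattus norvegicus as the target (a lower number here means that less compound is needed, a higher number that more compound is needed for the effect), compound 1 gives > 25 mg/kg, which is a limit of the assay and not a number.
Compound 2 `CCc1ccc2c(=O)c(-c3nn[nH]n3)c[nH]c2c1` — in this assay compound 2 gives < 5 mg/kg, likewise a limit and not a number.

Compound 1 therefore stands at the upper edge of what was tested; its reading is the limit described by the limit of > 25 mg/kg in this assay, at which 1 of the 2 values shown sits, rather than a measured dose. For the measured compounds named here, the only other value in this assay is the limit of compound 2 described by the limit of < 5 mg/kg in this assay, at which 1 of the 2 values shown sits, and the two compounds differ in more than one place, so no single step between measured compounds is available.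

Compound 3 `COc1cccc2cc(C(=O)O)cnc12` is the next candidate. The change from compound 1 is methoxy in place of fluoro on an aromatic carbon. Going by the values given here, with no measured step to lean on, the expected step of a number no higher from compound 1 to compound 3 (the limit leaves the size open) is set at none beyond the scatter, and compound 1 at a limit > 25 mg/kg makes a second limit the likelier outcome. The estimate for compound 3 in this assay is 25 mg/kg, with a range from 10 mg/kg to 60 mg/kg.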

Compound 3, minimum effective dose: 25 mg/kg
For compound 3 middle estimate and measured number coincide at the digits printed; the range from low to high includes it.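

In this assay, for the compounds shown here, compound 3 gives 25 mg/kg, which is a measured dose on the shared core and the first value that is not a limit. The change of fluoro to methoxy on this aromatic carbon, ortho to a fused ring and meta to a fused ring, reads as a number no higher from compound 1 to compound 3 (the limit leaves the size open), so only its direction is available and the step cannot be sized. The value for compound 1 is a limit, and the size stays unreadable because of that limit: the limit of > 25 mg/kg in this assay, at which 1 of the 3 values shown sits.

Going by these compounds alone, compound 2 differs from compound 3 in more than one place, so it says nothing about this position or about the methoxy group, and the series still holds no single-place step of readable size. Open too, going by these compounds, is how the dose would respond on the same aromatic carbon to plain hydrogen, chloro, ethoxy or an amine, and so whether the reading for compound 3 reflects methoxy specifically or any group larger than fluoro.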